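Ring-nitrogen substituent: compound 3 to compound 4

A few compounds are considered here, and "the series" means these few. Any claim that something is new, unique, unknown or untested is made for them only; others in the source may bear on it.

Compound 1 `Nc1ncc(-c2cccc(Cl)c2)c(-c2ccccc2)n1` and compound 2 `Nc1ncc(-c2ccncc2)c(-c2ccccc2)n1` both carry hydrogen on the ring nitrogen. In an assay on CHO cells for displacement of a labelled ligand from adenosine receptor A1 (Homo sapiens), read by scintillation counting, with a stated time of 1 h, tested at 1 uM (on this read-out lower numbers stand for less inhibition and higher numbers for more inhibition at the one concentration tested (going by the name of the read-out)), compound 1 gives > 80%, which is a limit of the assay and not a number. In this assay compound 2 gives > 80%, again a limit. Among the compounds with values here, compound 3 `O=C(Nc1ncc(-c2cccc(Cl)c2)c(-c2ccccc2)n1)C1CCC1` carries cyclobutylcarbonyl on that nitrogen and in this assay gives 52%; this is the only number in the set, the other two values sitting at the limit of > 80% in this assay, at which 2 of the 3 values shown sit. Within the data shown here, the single measured step, a number at least 28 percentage points lower from compound 1 to compound 3 (beyond the scatter), shows cyclobutylcarbonyl in place of hydrogen costing inhibition.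

Compound 4 `CNc1ncc(-c2cccc(Cl)c2)c(-c2ccccc2)n1` differs from compound 3 as follows: methyl in place of cyclobutylcarbonyl on a nitrogen on an aromatic ring. Among the measured compounds shown here, no measured step covers methyl on this nitrogen, so only a number at least 28 percentage points lower from compound 1 to compound 3 (beyond the scatter) bears on the change, and it points to cyclobutylcarbonyl as the group that lowered inhibition. Removing it in compound 4 is expected to recover part of that loss, an estimated rise of a number 16 percentage points higher from compound 3 to compound 4 (beyond the scatter) in this assay. For compound 4 an inhibition of 68% is expected, within 45% to 85%.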

Compound 4, a percentage reported as inhibition, at one concentration (the size of the read-out at that concentration, not a potency): 75%
For compound 4 the middle estimate is 7 percentage points below the measured one, within the range that was stated.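

In this assay, the series gains its first step between two numbers at this nitrogen on an aromatic ring: a number 23 percentage points higher from compound 3 to compound 4 (beyond the scatter). Set against hydrogen, the step to methyl reads a number at least 5 percentage points lower from compound 1 to compound 4 (that floor lies within the scatter), so it gives no sign that a small alkyl group costs inhibition here, and the clear loss so far belongs to cyclobutylcarbonyl alone. The size of any difference between methyl and hydrogen cannot be read, since compound 1 stands at a limit: the limit of > 80% in this assay, at which 2 of the 4 values shown sit.

The compounds shown do not separate the carbonyl of cyclobutylcarbonyl from its four-membered ring as the part that goes with the lower number; an acetyl group or a cyclobutylmethyl group on this nitrogen would do so. Also open, as far as these compounds go, is how a longer alkyl chain at this nitrogen would read.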